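Chalcone series: varying the aryl ketone on a stilbene core

The source may hold more compounds than are shown below. What is called first, only, known or untested is meant among the compounds shown, and "the series" means these compounds.

Measured so far:
compound 1 `COc1ccc(/C=C/c2cc(OC)cc(OC)c2/C=C/C(=O)c2ccc(Cl)c(Cl)c2)cc1` gives 7.5 ug/mL
compound 2 `COc1ccc(/C=C/c2cc(OC)cc(OC)c2/C=C/C(=O)c2ccc(C)cc2)cc1` gives 5.3 ug/mL
compound 3 `CCCCOc1ccc(C(=O)/C=C/c2c(/C=C/c3ccc(OC)cc3)cc(OC)cc2OC)cc1` gives 5.3 ug/mL

In a functional assay on B16-F10 cells (Mus musculus) for antiproliferative activity, read by MTT assay, with a stated time of 48 h (a lower number here means a stronger inhibitor, a higher number a weaker inhibitor), compound 3 stands level with compound 2 at the digits shown; the two give the lowest numbers of the three, though all three lie within the scatter of one another. Its smallest gap is no change at the digits printed from compound 2 to compound 3 (within the scatter) and its largest is a 1.4-fold lower number from compound 1 to compound 3 (0.15 log units; within the scatter). Compound 4 `COc1ccc(/C=C/c2cc(OC)cc(OC)c2/C=C/C(=O)c2ccccc2C)cc1` is the next variant, and the change is 2-methylphenyl in place of 4-butoxyphenyl on a carbonyl carbon. Every earlier step also swapped the group on the carbonyl carbon: a 1.4-fold lower number from compound 1 to compound 2 (0.15 log units; within the scatter), a 1.4-fold lower number from compound 1 to compound 3 (0.15 log units; within the scatter) and no change at the digits printed from compound 2 to compound 3 (within the scatter). None moved beyond the scatter, so in this assay no step beyond the scatter is expected for compound 4 in either direction. For compound 4 the expected step is a 1.0-fold higher number from compound 3 to compound 4 (0.02 log units; within the scatter). Compound 4 is estimated at 5.5 ug/mL, with a range from 2.5 ug/mL to 12 ug/mL.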

Compound 4, half-maximal inhibitory concentration: 6.1 ug/mL
For compound 4 the middle estimate is 1.1-fold (0.04 log units) below the measured one; the range from low to high includes it.
By their numbers in this assay, from the lowest: compounds 2, 3, 4 and 1 (each within the scatter of the next).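

In this assay, for the compounds shown here, compound 4 gives the first comparison of where the methyl sits on the phenyl group: 2-methylphenyl in place of 4-methylphenyl gives a 1.2-fold higher number from compound 2 to compound 4 (0.06 log units; within the scatter). Replacing 4-butoxyphenyl gives a 1.2-fold higher number from compound 3 to compound 4 (0.06 log units; within the scatter), and replacing 3,4-dichlorophenyl gives a 1.2-fold lower number from compound 1 to compound 4 (0.09 log units; within the scatter), so all four substituted phenyl groups on this carbonyl carbon now lie within the scatter of one another. No supporting data bear on these results.

Going by these compounds, it remains open whether an aminomethyl or carboxylic acid substituent on this phenyl group, or a cyclohexyl group in its place, would produce a step beyond the scatter.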